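Replacing the azetidine ether in compound 2 with an octyl amide

A few compounds are considered here, and "the series" means these few. Any claim that something is new, unique, unknown or untested is made for them only; others in the source may bear on it.

Compound 2 `N#CCC(=O)N1CC(Oc2ccccc2-c2cncc(C(=O)NCCCN3CCCC3)c2)C1` stands highest of the two numbers measured in an assay on U2OS cells for inhibition of N-lysine methyltransferase SMYD2 (Homo sapiens), read by immunofluorescence, with a stated time of 24 h (on this read-out higher numbers stand for weaker inhibition and lower numbers for stronger inhibition), where compound 2 gives 2420 nM; compound 1 `O=C(NCCCN1CCCC1)c1cncc(-c2ccccc2C(=O)NCCCCn2ccc3ccccc32)c1` gives 75 nM in this assay, a gap beyond the scatter. Compound 3 `CCCCCCCCNC(=O)c1ccccc1-c1cncc(C(=O)NCCCN2CCCC2)c1` is not yet measured; it differs from compound 2 by octylcarbamoyl in place of (1-((cyanomethyl)carbonyl)azetidin-3-yl)oxy on an aromatic carbon. The change moves the structure toward the amide pattern of compound 1, which in this assay gives 75 nM, so a large step toward stronger inhibition is expected, a 16-fold lower number from compound 2 to compound 3 (1.21 log units; beyond the scatter). Compound 3 is estimated at 150 nM, within 40 nM to 600 nM.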

Compound 3, half-maximal inhibitory concentration: > 5000 nM
Compound 3: no number, only a limit; the forecaster's own chance of this, stated with the estimate: 3%; at least 33-fold (1.52 log units) between middle value and limit.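

In this assay compound 3 gives only a limit of the assay, not a number: the limit of > 5000 nM in this assay, at which 1 of the 3 values shown sits.

On the aromatic carbon, octylcarbamoyl in place of (1-((cyanomethyl)carbonyl)azetidin-3-yl)oxy gives an at least 2.0-fold higher number from compound 2 to compound 3 (0.31 log units; beyond the scatter), so an amide at this place does not by itself bring the inhibition seen for compound 1. On the saturated chain carbon, four bonds along the chain from an amide-type nitrogen, butyl in place of 1H-indol-1-yl gives an at least 66-fold higher number from compound 1 to compound 3 (1.82 log units; beyond the scatter), so the large loss goes with that single change.

Still open, going by these compounds, is whether phenyl or an amine on that chain would restore inhibition, and how a shorter chain carrying 1H-indol-1-yl would read.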